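Phenyl replacing benzyl on the amide nitrogen of a chromone

The source may hold more compounds than are shown below. What is called first, only, known or untested is meant among the compounds shown, and "the series" means these compounds.

Of the compounds shown here, three sharing one core have been tested in a functional assay (QGY7701 cells, Homo sapiens) for inhibition, read by MTT assay, with a stated time of 48 h; a lower number here means a stronger inhibitor, a higher number a weaker inhibitor. Compound 1 `COc1ccc2c(=O)c(/C=C/C(=O)Nc3ccccc3)coc2c1` gives 14000 nM, compound 2 `COc1ccc2c(=O)c(/C=C/C(=O)Nc3ccccc3OC)coc2c1` gives 17600 nM, and compound 3 `COc1ccc2c(=O)c(/C=C/C(=O)NCc3ccc(C)cc3)coc2c1` gives 10200 nM. Compound 3 has the lowest number of the three, but its gap to compound 1 and the step of a 1.7-fold lower number from compound 2 to compound 3 (0.24 log units; within the scatter) both lie within the scatter, so no order among them can be drawn. Compound 4 `COc1ccc2c(=O)c(/C=C/C(=O)Nc3ccc(C)cc3)coc2c1` differs from compound 3 by 4-methylphenyl in place of 4-methylbenzyl on an amide-type nitrogen. For the measured compounds named here, the one measured step bearing on this is a 1.4-fold lower number from compound 1 to compound 3 (0.14 log units; within the scatter), where a phenyl on the same nitrogen was exchanged for the 4-methylbenzyl, and it stayed within the scatter. The expected step of a 1.2-fold higher number from compound 3 to compound 4 (0.09 log units; within the scatter) is therefore small, with no clear direction. Compound 4 is expected to give about 12500 nM in this assay, between 5000 nM and 30000 nM.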

Compound 4, half-maximal inhibitory concentration: 39300 nM
The estimate for compound 4 lay 3.1-fold (0.50 log units) below the measured number, outside the stated range (above it).
By their numbers in this assay, from the lowest: compounds 3, 1 and 2 (each within the scatter of the next); then compound 4.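

Adding a single methyl to the phenyl ring on the amide nitrogen produces the first clear differences in this set: there is a 2.8-fold higher number from compound 1 to compound 4 (0.45 log units; beyond the scatter), although the methoxy change from compound 1 to compound 2 stayed within the scatter. The 4-methylphenyl group also separates from 2-methoxyphenyl, with a 2.2-fold higher number from compound 2 to compound 4 (0.35 log units; beyond the scatter), and from 4-methylbenzyl, with a 3.9-fold higher number from compound 3 to compound 4 (0.59 log units; beyond the scatter), so this nitrogen's substituent can matter. No available evidence explains these steps.

From the compounds shown here alone, what an unsubstituted benzyl, a 4-methoxyphenyl or a longer phenethyl chain on this nitrogen would give remains open.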